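This account rests on a few compounds, and the source may have more. Where it says the series, first, only, none or still open, it means among the compounds named here.

Compound 1 `O=[N+]([O-])c1ccccc1CSc1nnc(-c2ccc3c(c2)OCCO3)n1-c1ccccc1` gives 26500 nM in a functional assay on BGC-823 cells (Homo sapiens) for antiproliferative activity, read by MTT assay, with a stated time of 24 h; on this read-out lower numbers stand for stronger inhibition and higher numbers for weaker inhibition.
Compound 2 `O=[N+]([O-])c1cccc(CSc2nnc(-c3ccc4c(c3)OCCO4)n2-c2ccccc2)c1` gives 30100 nM.

Compound 1 has the lower of the two numbers, yet the step of a 1.1-fold higher number from compound 1 to compound 2 (0.06 log units; within the scatter) lies within the scatter, so the two compounds cannot be told apart. Compound 3 `Fc1ccccc1CSc1nnc(-c2ccc3c(c2)OCCO3)n1-c1ccccc1` differs from compound 1 by fluoro in place of nitro on an aromatic carbon. For the measured compounds named here, the single measured step only moves the nitro group around the ring and does not bear on a swap of nitro for fluoro, so no direction can be read from it. The expected step is therefore a 1.1-fold higher number from compound 1 to compound 3 (0.05 log units; within the scatter), within the scatter. Compound 3 is estimated at 30000 nM, ranging from 9000 nM to 100000 nM.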

Compound 3, half-maximal inhibitory concentration: 18600 nM
Compound 3: middle estimate off by 1.6-fold (0.21 log units), on the high side; the range from low to high includes it.
By their numbers in this assay, from the lowest: compounds 3, 1 and 2 (each within the scatter of the next).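

Replacing 2-nitrophenyl with 2-fluorophenyl swaps nitro for a group with fewer heavy atoms and no hydrogen-bond acceptors, yet this assay cannot separate the two compounds: the step is a 1.4-fold lower number from compound 1 to compound 3 (0.15 log units; within the scatter). Changing the group and its place on the ring together also stays within the scatter, at a 1.6-fold lower number from compound 2 to compound 3 (0.21 log units; within the scatter), so nitro is not required for this level of activity among these compounds. No measurement at hand offers an explanation for this.

As far as these compounds go, whether an amine or a carboxylic acid on this aromatic carbon would move the number beyond the scatter remains open.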